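The source may report more compounds than this note shows. Statements on the series, on what has been measured and on what is new or still open speak of the compounds shown alone.

Measured compounds:
Compound 1, `O=C(Nc1cccc(-n2cc(-c3ccncc3)c(-c3cc(O)cc(Cl)c3)n2)c1)Nc1ccc(Cl)c(C(F)(F)F)c1`, gives 10.5%.
Compound 2, `COc1cc(Cl)cc(-c2nn(-c3cccc(NC(=O)Nc4ccc(Cl)c(C(F)(F)F)c4)c3)cc2-c2ccncc2)c1`, gives 0.3%.
Compound 3, `O=C(Nc1cccc(-n2cc(-c3ccncc3)c(-c3cc(O)cc(Cl)c3)n2)c1)c1cc(C(F)(F)F)cc(C(F)(F)F)c1`, gives 42.7%.

All three numbers come from a functional assay on NCI-H23 cells (Homo sapiens) for inhibition, read by sulforhodamine B assay, with a stated time of 48 h, tested at 10 uM; on this read-out higher numbers stand for a weaker effect at the one concentration tested and lower numbers for a stronger effect. Compound 1 and compound 2 share one core and differ only by methyl in place of hydrogen on an oxygen on an aromatic ring; that change made a step of a number 10.2 percentage points lower from compound 1 to compound 2 (beyond the scatter). Compound 3 is built on a different core, and the difference between the two cores is not broken down here; among the three it shows the highest number, beyond the scatter from both others. Compound 4, `COc1cc(Cl)cc(-c2nn(-c3cccc(NC(=O)c4cc(C(F)(F)F)cc(C(F)(F)F)c4)c3)cc2-c2ccncc2)c1`, is not yet measured. It differs from compound 3 by methyl in place of hydrogen on an oxygen on an aromatic ring, the same change as the one seen in the first pair, made at the same kind of place. Compound 4 is expected to move in the same direction, by an estimated step of a number 11.7 percentage points lower from compound 3 to compound 4 (beyond the scatter) in this assay. This expectation rests on the measured step of a number 10.2 percentage points lower from compound 1 to compound 2 (beyond the scatter). Compound 4 is therefore estimated at 31%, with a likely range from 14% to 50%.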

Compound 4, a percentage reported as activity, at one concentration (the size of the read-out at that concentration, not a potency): 72.1%
Compound 4: the middle estimate sits 41.1 percentage points below what was measured; measured number outside the range, above it.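

In this assay, the change from hydroxy to methoxy gave a number 29.4 percentage points higher from compound 3 to compound 4 (beyond the scatter), a weaker effect at the one concentration tested. The same change therefore did not carry over between these two cores, in either direction or size: the same change on two cores in this assay, a number 10.2 percentage points lower (beyond the scatter) from compound 1 to compound 2 and a number 29.4 percentage points higher (beyond the scatter) from compound 3 to compound 4, 39.6 percentage points apart, beyond the scatter of two such steps

Within the data shown here, with only two pairs, this shows that the step differs between these cores, but it does not show which part of the difference between them matters or how the change would behave on a further core. The compounds shown leave open whether a longer chain on that oxygen would follow either step. They also leave open how an amine in place of the hydroxy would behave on each core.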